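Extending the chain on the ring nitrogen of compound 3

A few compounds are considered here, and "the series" means these few. Any claim that something is new, unique, unknown or untested is made for them only; others in the source may bear on it.

Compound 1 `Cc1cccc(CSc2nc3cc(NC(=O)C4CC4)ccc3n2C(C)C)c1` — an assay on isolated protein for inhibition of Gonadotropin-releasing hormone receptor (Homo sapiens); on this read-out lower numbers stand for stronger inhibition and higher numbers for weaker inhibition: 6500 nM
Compound 2 `CC(C)n1c(SCc2ccccc2Cl)nc2cc(NC(=O)C3CC3)ccc21` — this assay: 6300 nM
Compound 3 `CCn1c(SCc2cc([N+](=O)[O-])ccc2OC)nc2cc(NC(=O)NC(C)(C)C)ccc21` — this assay: 42 nM

Compounds 1 and 2 sit within the scatter of each other, as a 1.0-fold lower number from compound 1 to compound 2 (0.01 log units; within the scatter) shows. Compound 3 gives the lowest number of the three, and both other compounds lie far above it, well beyond the scatter. Compound 4 `CCCCCn1c(SCc2cc([N+](=O)[O-])ccc2OC)nc2cc(NC(=O)NC(C)(C)C)ccc21` differs from compound 3 by propyl in place of hydrogen on a saturated chain carbon, two bonds along the chain from an aromatic nitrogen, which cut one bond further out reads ethyl to pentyl. Going by the values given here, the single measured step, from compound 1 to compound 2, alters the group on the chain carbon bound to sulfur and says nothing about this nitrogen chain. Among the compounds with values here, with no step bearing on it, compound 4 is expected to stay near compound 3, an estimated 1.4-fold higher number from compound 3 to compound 4 (0.15 log units; within the scatter). Compound 4 is therefore estimated at 60 nM, within 15 nM to 250 nM.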

Compound 4, half-maximal inhibitory concentration: 210 nM
The estimate for compound 4 lay 3.5-fold (0.54 log units) below the measured number, within the range that was stated.
By their numbers in this assay, from the lowest: compound 3; then compound 4; then compounds 2 and 1 (each within the scatter of the next).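

Lengthening the chain on the ring nitrogen from ethyl to pentyl gives a 5.0-fold higher number from compound 3 to compound 4 (0.70 log units; beyond the scatter), so this position, untouched by the earlier step, does respond to the change in this assay. The added propyl carries the chain further out and weakens inhibition by a modest but real margin. Nothing in the data shown gives a cause for this step.

The compounds shown leave open whether a propyl or butyl chain on this nitrogen, or a pentyl chain ending in an amine or a carboxylic acid, would read like ethyl or like pentyl.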